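Notes on compound 4 and its expected binding

A few compounds are considered here, and "the series" means these few. Any claim that something is new, unique, unknown or untested is made for them only; others in the source may bear on it.

Among the measured compounds shown here, compound 1 `CCC(C)(C)Cc1c[nH]c(CCc2ccc(-n3ccnn3)cc2)n1` carries the highest number of the three measured members; in an in vitro assay on CHO cells for displacement of a labelled ligand from Bombesin receptor subtype-3 (Homo sapiens), read by scintillation counting, with a stated time of 2 h (on this read-out lower numbers stand for stronger inhibition and higher numbers for weaker inhibition), compound 1 gives 390 nM. The nearest neighbour is compound 2 `CCC(C)(C)Cc1c[nH]c(CCc2ccc(-c3cccc(C#N)n3)cc2)n1`, which in this assay gives 140 nM, a step of a 2.8-fold lower number from compound 1 to compound 2 (0.44 log units; beyond the scatter). The furthest is compound 3 `CCC(C)(C)Cc1c[nH]c(CCc2ccc(-c3cccc(N)n3)cc2)n1`, which gives 7.3 nM in this assay; that step is a 53-fold lower number from compound 1 to compound 3 (1.73 log units; beyond the scatter), and the remaining measured step is a 19-fold lower number from compound 2 to compound 3 (1.28 log units; beyond the scatter).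

Compound 4 `CCC(C)(C)Cc1c[nH]c(CCc2ccc(-c3ccns3)cc2)n1` is not yet measured. It differs from compound 1 by 1,2-thiazol-5-yl in place of 1H-1,2,3-triazol-1-yl on an aromatic carbon, placed on an aromatic carbon of a six-membered aromatic ring of carbon only, para to a large group. Both measured steps from compound 1 replace the same 1H-1,2,3-triazol-1-yl ring with a six-membered aromatic group, and both lower the number; the larger of them rests on a 6-aminopyridin-2-yl group, which compound 4 lacks. The entering 1,2-thiazol-5-yl is, like the leaving group, a five-membered aromatic ring. A modest downward step at most is therefore expected, of about the size seen from compound 1 to compound 2 or smaller. The expectation for compound 4 in this assay is 250 nM, with a range from 80 nM to 800 nM, which corresponds to an expected step of a 1.6-fold lower number from compound 1 to compound 4 (0.19 log units; within the scatter).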

Compound 4, half-maximal inhibitory concentration: 11 nM
Beside the measured number, compound 4's estimate is 23-fold (1.36 log units) above it; measured number below the stated range.
By their numbers in this assay, from the lowest: compounds 3 and 4 (each within the scatter of the next); then compound 2; then compound 1.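

In this assay, the step of a 35-fold lower number from compound 1 to compound 4 (1.55 log units; beyond the scatter) shows that this position, on an aromatic carbon of a six-membered aromatic ring of carbon only, para to a large group, can respond strongly to an exchange between two five-membered aromatic rings of equal heavy-atom count; a six-membered aromatic group is therefore not required for a low number here. The step of a 1.5-fold higher number from compound 3 to compound 4 (0.18 log units; within the scatter) gives no order between these two compounds, while a 13-fold lower number from compound 2 to compound 4 (1.10 log units; beyond the scatter) is large, so the low numbers in this small set are not confined to the 6-aminopyridin-2-yl group and 1,2-thiazol-5-yl reaches them with no hydrogen-bond donor in the entering group. No measurement at hand bears on what lies behind the change from 1H-1,2,3-triazol-1-yl to 1,2-thiazol-5-yl.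

The compounds shown leave open whether the sulfur atom or the arrangement of the ring atoms carries this step, which a thiophene ring or a furan ring in the same place could begin to separate. They also leave open whether an amino group carried on the 1,2-thiazole ring would lower the number further.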